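Shifting the chloro substituent on the chlorophenyl group

The compounds below may be only part of what the source reports. "The series", "measured", "known", "first", "only" and "open" are said of these compounds alone.

Three compounds share one core and differ only in the group carried on a nitrogen on an aromatic ring. Compound 1 `Fc1ccc(Nc2nc(-c3cccc(F)c3)nc3ccc(F)cc23)cc1` reaches only a limit of a functional assay on COLO 205 cells (Homo sapiens) for cytotoxicity, read by MTT assay, with a stated time of 48 h (on this read-out lower numbers stand for stronger inhibition and higher numbers for weaker inhibition), giving > 50000 nM. Compound 2 `Fc1cccc(-c2nc(Nc3ccc(Cl)cc3)c3cc(F)ccc3n2)c1` gives 32600 nM. Compound 3 `Fc1cccc(-c2nc(Nc3cccc(Cl)c3)c3cc(F)ccc3n2)c1` again reaches only a limit, at > 50000 nM. Two of the three values thus sit at the limit of > 50000 nM in this assay, at which 2 of the 3 values shown sit. Of the measured steps, an at least 1.5-fold higher number from compound 2 to compound 3 (0.18 log units; that floor lies within the scatter), while a step that the two limits leave unreadable from compound 1 to compound 3. Compound 4 `Fc1cccc(-c2nc(Nc3ccccc3Cl)c3cc(F)ccc3n2)c1` differs from compound 3 by 2-chlorophenyl in place of 3-chlorophenyl on a nitrogen on an aromatic ring. For the measured compounds named here, with compound 3 known only as a limit and the one readable step small, no change beyond the scatter is expected, so for compound 4 the estimated step is an at least 1.1-fold lower number from compound 3 to compound 4 (0.04 log units; that floor lies within the scatter). Compound 4 is therefore expected to give about 45000 nM, between 15000 nM and 120000 nM, quite possibly again a limit.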

Compound 4, half-maximal inhibitory concentration: > 50000 nM
Compound 4: a limit, no number; the forecaster's own chance of this, stated with the estimate: 60%; middle value at least 1.1-fold (0.04 log units) away from the limit.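

With 2-chlorophenyl on the nitrogen, compound 4 also gives only a limit in this assay, so of the three chlorophenyl compounds only compound 2, with 4-chlorophenyl, gives a number. For the compounds shown here, the one step that can be read is an at least 1.5-fold higher number from compound 2 to compound 4 (0.18 log units; that floor lies within the scatter). The steps to compound 4 from the other two compounds cannot be read, and most of the series now stands at one limit: the limit of > 50000 nM in this assay, at which 3 of the 4 values shown sit.

On these data alone, whether a methoxy group or an amine in place of the chloro would give a readable number stays open. So do the true values of compound 3 and compound 4.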